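Trimming a Methoxy Group on an Adenosine Receptor Ligand

The source may report more compounds than this note shows. Statements on the series, on what has been measured and on what is new or still open speak of the compounds shown alone.

Measured so far:
compound 1, `O=C(Nc1nn(-c2ccccc2)c(=O)c2ccccc12)c1ccccc1`, 1100 nM
compound 2, `COc1ccc(OC)c(NC(=O)Nc2nn(-c3ccccc3)c(=O)c3ccccc23)c1`, 0.776 nM

In an assay on CHO cells for displacement of a labelled ligand from adenosine receptor A3 (Homo sapiens) (on this read-out higher numbers stand for weaker inhibition and lower numbers for stronger inhibition), compound 1 gives 1100 nM, and compound 2 gives 0.776 nM. Compound 2 stands lowest of the two numbers, and its gap to compound 1 lies far beyond the scatter of repeated measurements. Compound 3, `COc1ccc(NC(=O)Nc2nn(-c3ccccc3)c(=O)c3ccccc23)cc1`, has not yet been measured. It differs from compound 2 in one place: 4-methoxyphenyl in place of 2,5-dimethoxyphenyl on an amide-type nitrogen. Within the data shown here, no pair of measured compounds that differ in this way exists, so the size of this step cannot be read off the numbers at hand. Among the measured compounds shown here, compound 3 keeps the urea linkage that compound 2 carries, and that linkage is the only feature that separates compound 2 from compound 1. The change in this assay from compound 2 to compound 3 is expected to be a modest rise in the number, a 6.4-fold higher number from compound 2 to compound 3 (0.81 log units; beyond the scatter), since one methoxy group fewer is a small change. Compound 3 is therefore expected to give about 5 nM, within a range from 0.8 nM to 40 nM.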

Compound 3, inhibition constant: 60.6 nM
Beside the measured number, compound 3's estimate is 12-fold (1.08 log units) below it; the measured number lies above the stated range.
By their numbers in this assay, from the lowest: compound 2; then compound 3; then compound 1.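

In this assay, replacing 2,5-dimethoxyphenyl with 4-methoxyphenyl on an amide-type nitrogen gives a 78-fold higher number from compound 2 to compound 3 (1.89 log units; beyond the scatter), which shows that this position is highly sensitive to the methoxy pattern on the ring, even though the urea linkage stays in place. The other step, (4-methoxyphenyl)amino in place of phenyl on a carbonyl carbon, gives an 18-fold lower number from compound 1 to compound 3 (1.26 log units; beyond the scatter), so this change counts as well, and both steps are large enough that neither the group on the carbonyl carbon nor the methoxy pattern can be dismissed as a minor detail. The compounds offer no independent measurement that could explain why either change has such a large effect.

Compound 3 differs from compound 2 both in how many methoxy groups it carries and in where its methoxy group sits, so these two changes cannot be separated here. A plain phenyl, a 2-methoxyphenyl or a 2,5-dichlorophenyl on the same nitrogen could help to separate them, and could also show whether methoxy itself matters or whether other groups on the ring would serve equally well.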